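Reshaping the Amide Nitrogen Substituent of Compound 2

This account rests on a few compounds, and the source may have more. Where it says the series, first, only, none or still open, it means among the compounds named here.

Among the measured compounds shown here, compound 2 `Cc1ccc(OCC(=O)N(Cc2cccs2)C(C)(C)C)cc1` stands at the high end of the two numbers so far: in an assay on HEK293 cells for agonist activity at transient receptor potential cation channel subfamily M member 8 (Homo sapiens), read by fluorescence and calcium flux, with a stated time of 15 min (a lower number here means that less compound is needed, a higher number that more compound is needed for the effect), compound 2 gives 11000 nM, while its nearest neighbour compound 1 `CON(Cc1cccs1)C(=O)COc1ccc(C)cc1` gives 10 nM. For the measured compounds named here, the one step joining them, a 1100-fold higher number from compound 1 to compound 2 (3.04 log units; beyond the scatter), came from tert-butyl in place of methoxy on an amide-type nitrogen. Compound 3 `COCCN(Cc1cccs1)C(=O)COc1ccc(C)cc1` has not been measured; its difference from compound 2 is 2-methoxyethyl in place of tert-butyl on an amide-type nitrogen. That single measured step bears directly on the new compound, showing that the group on this nitrogen can shift the number greatly, and compound 3 gives up the tert-butyl that accompanied the high number of compound 2. Since 2-methoxyethyl is not the methoxy of compound 1, a full return is uncertain. A large downward step is expected, a 37-fold lower number from compound 2 to compound 3 (1.56 log units; beyond the scatter). Compound 3 is therefore estimated at 300 nM, within 30 nM to 3000 nM.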

Compound 3, half-maximal effective concentration: 400 nM
For compound 3 the middle estimate is 1.3-fold (0.12 log units) below the measured one, within the range that was stated.
By their numbers in this assay, from the lowest: compound 1; then compound 3; then compound 2.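

The step of a 28-fold lower number from compound 2 to compound 3 (1.44 log units; beyond the scatter) in this assay shows that the number at this amide-type nitrogen can move strongly even when the heavy-atom count of the group stays the same, since tert-butyl and 2-methoxyethyl match on that count and differ in carbon, oxygen and hydrogen-bond acceptors. The drop is only partial, however: a 40-fold higher number from compound 1 to compound 3 (1.60 log units; beyond the scatter) separates 2-methoxyethyl from methoxy, so two groups that both carry an oxygen still give clearly different numbers. Compound 3 therefore sits between the other two compounds, with its steps to both beyond the scatter. No supporting measurement accompanies these numbers that would explain the differences between these groups. The compounds shown leave open how a plain butyl chain, which would separate the oxygen from the chain, would compare at this nitrogen, and how ethoxy or 2-hydroxyethyl would fall relative to methoxy and 2-methoxyethyl.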